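The source may report more compounds than this note shows. Statements on the series, on what has been measured and on what is new or still open speak of the compounds shown alone.

Measured so far in a functional assay on LNCaP cells (Homo sapiens) for antiproliferative activity, read by propidium iodide staining, with a stated time of 96 h; on this read-out lower numbers stand for stronger inhibition and higher numbers for weaker inhibition

Compound 1 (`CC(O)(CSc1ccc(C(F)(F)F)cc1)C(=O)Nc1ccc(S(F)(F)(F)(F)F)cc1`) gives 17000 nM

Compound 2 (`CC(O)(CSc1ccc(OC(F)(F)F)cc1)C(=O)Nc1ccc(S(F)(F)(F)(F)F)cc1`) gives 16100 nM

Compound 1 has only compound 2 for comparison, and the gap between them is a 1.1-fold lower number from compound 1 to compound 2 (0.02 log units; within the scatter), so neither stands apart from the other. That step places trifluoromethoxy in place of trifluoromethyl on an aromatic carbon.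

Compound 3 (`CC(O)(CSc1ccc(C(F)(F)F)cn1)C(=O)Nc1ccc(S(F)(F)(F)(F)F)cc1`) keeps the core of compound 1 and changes one part of it, with 5-(trifluoromethyl)pyridin-2-yl in place of 4-(trifluoromethyl)phenyl on a sulfur. Among the compounds with values here, no measured step makes this same change, so the data offer only indirect guidance. Within the data shown here, the one step available, a 1.1-fold lower number from compound 1 to compound 2 (0.02 log units; within the scatter), alters a different part of the molecule and bears on the new change only loosely. On that thin basis, no step beyond the scatter is expected in this assay, and no direction can be favoured with confidence. The expected step is a 1.1-fold higher number from compound 1 to compound 3 (0.02 log units; within the scatter), an estimate that carries wide uncertainty. Compound 3 is estimated at 18000 nM, with an expected range from 8000 nM to 40000 nM.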

Compound 3, half-maximal inhibitory concentration: 12300 nM
The estimate for compound 3 lay 1.5-fold (0.17 log units) above the measured number, and the stated range covers the measured number.
By their numbers in this assay, from the lowest: compounds 3, 2 and 1 (each within the scatter of the next).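

On the sulfur whose other neighbour is a saturated chain carbon, 5-(trifluoromethyl)pyridin-2-yl stands in place of 4-(trifluoromethyl)phenyl in this assay with a 1.4-fold lower number from compound 1 to compound 3 (0.14 log units; within the scatter), so exchanging a ring carbon for a nitrogen, which adds one hydrogen-bond acceptor by the count, does not separate the two compounds. The earlier pair changed only the group carried by the aromatic ring, whereas this step alters the ring itself, and the read-out again stays within the scatter. No measured evidence bears on this result, so what lies behind it remains unknown.

The compounds shown leave open whether any change at this position can move the number beyond the scatter, for instance a nitrile or an amine in place of the trifluoromethyl on the 5-(trifluoromethyl)pyridin-2-yl ring. They also leave open whether the near-equal numbers would persist with a sulfonyl group in place of the sulfur, since that link is the same in compound 1, compound 2 and compound 3.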